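Moving the trifluoromethyl group on the phenyl ring

The source may hold more compounds than are shown below. What is called first, only, known or untested is meant among the compounds shown, and "the series" means these compounds.

Compound 1 `CCCS(=O)(=O)Nc1ccc(F)c(C(=O)c2n[nH]c3ncc(-c4ccccc4O)cc23)c1F`: 9%
Compound 2 `CCCS(=O)(=O)Nc1ccc(F)c(C(=O)c2n[nH]c3ncc(-c4cccc(N(C)C)c4)cc23)c1F`: 26%
Compound 3 `CCCS(=O)(=O)Nc1ccc(F)c(C(=O)c2n[nH]c3ncc(-c4cccc(C(F)(F)F)c4)cc23)c1F`: 57%

These three share one core and differ only in the aryl group joined to it; all were tested in an assay for binding affinity to dual specificity mitogen-activated protein kinase kinase 4 (Homo sapiens), read by KINOMEscan, tested at 100 nM; on this read-out higher numbers stand for a weaker effect at the one concentration tested and lower numbers for a stronger effect. Compound 3 gives the highest number of the three, and so the weakest effect: both a number 48 percentage points higher from compound 1 to compound 3 (beyond the scatter) and a number 31 percentage points higher from compound 2 to compound 3 (beyond the scatter) lie beyond the scatter, and both are large. Compound 4 `CCCS(=O)(=O)Nc1ccc(F)c(C(=O)c2n[nH]c3ncc(-c4ccc(C(F)(F)F)cc4)cc23)c1F` has not been measured; it differs from compound 3 in this way: 4-(trifluoromethyl)phenyl in place of 3-(trifluoromethyl)phenyl on an aromatic carbon. Neither measured step changes where the trifluoromethyl sits on its phenyl ring; each swaps one whole group for another. Going by the values given here, with no step of this kind to lean on, compound 4 is expected to stay near compound 3, the expected step being a number 2 percentage points lower from compound 3 to compound 4 (within the scatter). Compound 4 is estimated at 55%, expected to lie between 25% and 85%.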

Compound 4, a percentage reported as activity, at one concentration (the size of the read-out at that concentration, not a potency): 29%
Estimate against measurement, compound 4: 26 percentage points above; the measured number falls inside the stated range.
By their numbers in this assay, from the lowest: compound 1; then compounds 2 and 4 (each within the scatter of the next); then compound 3.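

Moving the trifluoromethyl group on its phenyl ring matters on its own: with the same atoms joined differently, this assay gives a number 28 percentage points lower from compound 3 to compound 4 (beyond the scatter). This move closes most of the distance to the dimethylamino compound, with a number 3 percentage points higher from compound 2 to compound 4 (within the scatter), but the hydroxyl compound remains apart, with a number 20 percentage points higher from compound 1 to compound 4 (beyond the scatter). Nothing available explains this shift. From the compounds shown here alone, whether other groups on the phenyl ring, such as methoxy or a carboxylic acid, respond similarly to a change of place stays open.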